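Notes on the shared core: compound 4 against compound 1

The source may hold more compounds than are shown below. What is called first, only, known or untested is meant among the compounds shown, and "the series" means these compounds.

Measured in a functional assay on HepG2 cells (Homo sapiens) for antiproliferative activity, read by MTT assay, with a stated time of 48 h; a higher number here means a weaker inhibitor, a lower number a stronger inhibitor:
compound 1 `COc1ccc(NC(=O)Nc2cccc(CNc3nccnc3Cl)c2)cc1` — 12000 nM
compound 2 `O=C(Nc1cccc(CNc2nccnc2Cl)c1)NC1CCCC1` — 18400 nM
compound 3 `O=C(Nc1cccc(CNc2nccnc2Cl)c1)NC1CCCCC1` — reported only as a limit, > 40000 nM

Compound 1 holds the lowest of the two numbers in this assay, and the step to compound 2 is within the scatter: a 1.5-fold higher number from compound 1 to compound 2 (0.19 log units; within the scatter). The entry for compound 3 is a limit of this assay and not a number (the limit of > 40000 nM in this assay, at which 1 of the 3 values shown sits). The steps to it, an at least 3.3-fold higher number from compound 1 to compound 3 (0.52 log units; beyond the scatter) and an at least 2.1-fold higher number from compound 2 to compound 3 (0.33 log units; beyond the scatter), are at least modest. Compound 4 `O=C(Nc1cccc(CNc2nccnc2Cl)c1)Nc1ccc(Cl)cc1Br` differs from compound 1 thus: 2-bromo-4-chlorophenyl in place of 4-methoxyphenyl on an amide-type nitrogen. The measured steps exchange 4-methoxyphenyl for cyclopentyl or cyclohexyl; none keeps an aromatic group as this one does, so they bear on it only loosely. For compound 4 in this assay the expected step is a 1.3-fold lower number from compound 1 to compound 4 (0.12 log units; within the scatter), within the scatter. The estimate for compound 4 is 9000 nM, with a range of 3000 nM to 30000 nM.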

Compound 4, half-maximal inhibitory concentration: 6720 nM
Estimate against measurement, compound 4: 1.3-fold (0.13 log units) above; low and high end bracket the measured number.
By their numbers in this assay, from the lowest: compounds 4, 1 and 2 (each within the scatter of the next, the first and the last beyond it). At a limit, above all of these: compound 3.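

Keeping an aromatic ring on the amide-type nitrogen, 2-bromo-4-chlorophenyl in place of 4-methoxyphenyl gives a 1.8-fold lower number from compound 1 to compound 4 (0.25 log units; within the scatter) in this assay, so these two substituted rings cannot be told apart here. The new ring does separate from cyclopentyl and cyclohexyl, with a 2.7-fold lower number from compound 2 to compound 4 (0.44 log units; beyond the scatter) and an at least 5.9-fold lower number from compound 3 to compound 4 (0.77 log units; beyond the scatter), yet compound 1 stays within the scatter of compound 2, so aromatic against saturated is no clean divide. The entry for compound 3 is a limit and not a number: the limit of > 40000 nM in this assay, at which 1 of the 4 values shown sits.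

Open, on these data alone, is whether either halogen alone, as in 4-chlorophenyl or 2-bromophenyl, reads like the pair. Also open, as far as these compounds go, is how unsubstituted phenyl, or a ring carrying an amine or a carboxylic acid, would read.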